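A few compounds are considered here, and "the series" means these few. Any claim that something is new, unique, unknown or untested is made for them only; others in the source may bear on it.

Measured in an ADME assay on the whole organism (strain CD-1) for pharmacokinetics, with Mus musculus as the target, at a dose of 3 mg/kg by the intravenous route; on this read-out lower numbers stand for lower exposure and higher numbers for higher exposure at the dose given:
- Compound 1 `CC(CCCCOc1ccccc1CN(C)C(=O)c1ccc(-c2ccco2)cc1)C(=O)O`: 11400 ng.h/mL
- Compound 2 `CN(Cc1ccccc1OCCCCC(C)(C)C(=O)O)C(=O)c1ccc(-c2ccco2)cc1`: 48400 ng.h/mL

Of these two, compound 2 has the higher number, at 48400 ng.h/mL, and the gap to compound 1 lies beyond the usual scatter. The next compound, compound 3 `C[C@H](CCCOc1ccccc1CN(C)C(=O)c1ccc(-c2ccco2)cc1)CC(=O)O`, has not yet been measured in this assay. Its structural change is 1-(carboxymethyl)ethyl in place of 2-carboxy-2-methylpropyl on a saturated chain carbon, three bonds along the chain from an oxygen on an aromatic ring: 1-(carboxymethyl)ethyl in place of 2-carboxy-2-methylpropyl, on a saturated chain carbon, three bonds along the chain from an oxygen on an aromatic ring. The entering group brings one defined stereocentre.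

Among the compounds with values here, only one measured step bears on this change: a 4.2-fold higher number from compound 1 to compound 2 (0.63 log units; beyond the scatter), a modest step made by methyl in place of hydrogen on a saturated chain carbon bound to a carbonyl carbon. Compound 3 has no methyl on the carbon bound to its carbonyl carbon, so that step is expected to be lost and somewhat exceeded in reverse. Within the data shown here, no measured compound carries the entering group, so this expectation remains uncertain. The estimate is a 4.8-fold lower number from compound 2 to compound 3 (0.68 log units; beyond the scatter), an expected fall beyond the scatter. For compound 3 the estimated value is 10000 ng.h/mL, with an expected range from 3500 ng.h/mL to 28000 ng.h/mL.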

Compound 3, area under the concentration-time curve: 77700 ng.h/mL
Estimate against measurement, compound 3: 7.8-fold (0.89 log units) below; the measured number lies above the stated range.
By their numbers in this assay, from the lowest: compound 1; then compounds 2 and 3 (each within the scatter of the next).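

In this assay, 1-(carboxymethyl)ethyl in place of 2-carboxy-2-methylpropyl, on a saturated chain carbon, three bonds along the chain from an oxygen on an aromatic ring, gives a 1.6-fold higher number from compound 2 to compound 3 (0.21 log units; within the scatter). Compound 2 and compound 3 therefore cannot be told apart on this read-out, and the high numbers at this position do not depend on the 2-carboxy-2-methylpropyl group alone. Set against the 2-carboxypropyl group of compound 1, the same entering group gives a 6.8-fold higher number from compound 1 to compound 3 (0.83 log units; beyond the scatter), so with one methyl on the acid-bearing chain in both compounds, where that methyl stands goes with a clear difference here, and nothing shown offers an explanation for this result.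

Going by these compounds, the defined stereocentre of compound 3 appears in one form only, so the opposite form at that carbon remains open, as does a chain that carries no methyl at all. Also open, on these data alone, is how this read-out would respond to a longer chain, or to an amide or a tetrazole in place of the carboxylic acid.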